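Chain extension in a cinnamanilide series: lipophilicity notes

The compounds below may be only part of what the source reports. "The series", "measured", "known", "first", "only" and "open" are said of these compounds alone.

Measured so far: compound 1 `COc1cc(/C=C/C(=O)Nc2ccccc2)ccc1OCCCCCCN1CCCC1` gives 1.76 in a physicochemical assay for lipophilicity, using the shake flask method, measured as octanol-water partition, at pH 7.4; a lower number here means a more polar compound, a higher number a more lipophilic compound; compound 2 `CCN(CC)CCCCCCCCOc1ccc(/C=C/C(=O)Nc2ccccc2)cc1OC` gives 1.75.

Compound 2 stands at the lower of the two numbers in this assay, though the step of a number 0.01 log units lower from compound 1 to compound 2 (within the scatter) is within the scatter. Compound 3 `CCN(CC)CCCCCCCCCCOc1ccc(/C=C/C(=O)Nc2ccccc2)cc1OC` differs from compound 2 by 2-(diethylamino)ethyl in place of diethylamino on a saturated chain carbon, eight bonds along the chain from an oxygen on an aromatic ring. Among the measured compounds shown here, the only measured step, a number 0.01 log units lower from compound 1 to compound 2 (within the scatter), also lengthened the chain but changed the amine at the same time, so it bears only loosely on the present change. A moderate rise in this assay is expected, a number 0.55 log units higher from compound 2 to compound 3 (beyond the scatter). Compound 3 is estimated at 2.3, with a range from 1.7 to 2.9.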

Compound 3, partition coefficient: 1.83
Compound 3: middle estimate off by 0.47 log units, on the high side; low and high end bracket the measured number.
By their numbers in this assay, from the lowest: compounds 2, 1 and 3 (each within the scatter of the next).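

In this assay, 2-(diethylamino)ethyl in place of diethylamino, with the amine held the same, gives a number 0.08 log units higher from compound 2 to compound 3 (within the scatter), so this change at this chain position does not separate the two compounds. Likewise, 4-(diethylamino)butyl in place of pyrrolidin-1-yl gives a number 0.07 log units higher from compound 1 to compound 3 (within the scatter), which leaves all three compounds within the scatter of one another. No supporting data bear on this result. Going by these compounds, whether a longer chain, or a carboxylic acid in place of the diethylamino group, would stand apart from these three numbers remains open.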